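A Smaller Aryl Amide on the Shared Core

A few compounds are considered here, and "the series" means these few. Any claim that something is new, unique, unknown or untested is made for them only; others in the source may bear on it.

Compound 2 `O=C(/C=C/c1ccc(Cl)cc1)Nc1cc(Sc2ncn[nH]2)c(O)c2ccccc12` gives 31.8% in an assay on isolated protein for inhibition of RAC-alpha serine/threonine-protein kinase (Homo sapiens), read by fluorescence, with a stated time of 30 min, tested at 10 uM (on this read-out lower numbers stand for less inhibition and higher numbers for more inhibition at the one concentration tested (going by the name of the read-out)), and compound 1 `O=C(Nc1cc(Sc2ncn[nH]2)c(O)c2ccccc12)c1ccc2ccccc2c1` gives 41.6%; the step of a number 9.8 percentage points lower from compound 1 to compound 2 (within the scatter) lies within the scatter, so the two compounds are not separated by this read-out. Compound 3 `Cc1cccc(C(=O)Nc2cc(Sc3ncn[nH]3)c(O)c3ccccc23)c1` differs from compound 2 in one place: 3-methylphenyl in place of 2-(4-chlorophenyl)ethenyl on a carbonyl carbon. Going by the values given here, the only measured step that bears on this change also exchanged the group on the carbonyl carbon. Because a number 9.8 percentage points lower from compound 1 to compound 2 (within the scatter) stayed within the scatter, the step of a number 3.2 percentage points higher from compound 2 to compound 3 (within the scatter) is expected to stay within it as well. Compound 3 is therefore estimated at 35%, with a range from 18% to 52%.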

Compound 3, a percentage reported as inhibition, at one concentration (the size of the read-out at that concentration, not a potency): 20.2%
Beside the measured number, compound 3's estimate is 14.8 percentage points above it; low and high end bracket the measured number.
By their numbers in this assay, from the lowest: compound 3; then compounds 2 and 1 (each within the scatter of the next).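

On the carbonyl carbon next to the amide-type nitrogen, the group can now separate compounds in this assay: the step of a number 11.6 percentage points lower from compound 2 to compound 3 (beyond the scatter) and the step of a number 21.4 percentage points lower from compound 1 to compound 3 (beyond the scatter) both lie beyond the scatter and are modest, while the earlier exchange at this place stayed within it. Nothing measured here gives a reason for these steps. The compounds shown leave open how the read-out responds on this carbonyl carbon to a group carrying an amine or a carboxylic acid, or to a plain phenyl without the methyl.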